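Ring enlargement on the terminal carbonyl of compound 3

A few compounds are considered here, and "the series" means these few. Any claim that something is new, unique, unknown or untested is made for them only; others in the source may bear on it.

Series notes. Compound 1 `COCC(=O)N1CCC(NS(=O)(=O)c2ccc(NC(=O)c3ccccc3C)c3ccccc23)CC1` gives 15.8 nM in an assay on L1.2 cells for binding affinity to C-C chemokine receptor type 8 (Homo sapiens); a higher number here means a weaker inhibitor, a lower number a stronger inhibitor. Among the compounds with values here, compound 3 `Cc1ccccc1C(=O)Nc1ccc(S(=O)(=O)NC2CCN(C(=O)N3CCCC3)CC2)c2ccccc12` gives 1.1 nM in this assay, the lowest of the two single numbers in hand; the step of a 14-fold lower number from compound 1 to compound 3 (1.16 log units; beyond the scatter) is the only one-place change measured so far. Compound 2 `Cc1ccccc1C(=O)Nc1ccc(S(=O)(=O)NC2CCN(C(=O)[C@@H]3CCCN3)CC2)c2ccccc12` has several entries in this assay, 0.7 nM; 1 nM (2 entries), and in this assay compound 2 and compound 3 sit within the scatter of each other, so no order between them is claimed. The repeat spread for compound 2 is shown by the several entries of compound 2 in this assay, 0.7 nM; 1 nM (2 entries).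

Compound 4 `Cc1ccccc1C(=O)Nc1ccc(S(=O)(=O)NC2CCN(C(=O)N3CCCCC3)CC2)c2ccccc12` differs from compound 3 by piperidin-1-yl in place of pyrrolidin-1-yl on a carbonyl carbon. Within the data shown here, no measured step changes a ring size on this carbonyl; the one measured step, a 14-fold lower number from compound 1 to compound 3 (1.16 log units; beyond the scatter), replaces methoxymethyl with pyrrolidin-1-yl and is large, but it does not tell how a one-atom enlargement of the ring will read. Compound 2 and compound 3 show that two different nitrogen rings on this carbonyl give numbers within the scatter of each other. For compound 4 a step of no more than the scatter is therefore expected, a 1.4-fold higher number from compound 3 to compound 4 (0.13 log units; within the scatter). Compound 4 is estimated at 1.5 nM in this assay, with a range from 0.5 nM to 5 nM.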

Compound 4, inhibition constant: 4.2 nM
Estimate against measurement, compound 4: 2.8-fold (0.45 log units) below; the measured number falls inside the stated range.
By their numbers in this assay, from the lowest: compound 3; then compound 4; then compound 1.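

Within the data shown here, the step of a 3.8-fold higher number from compound 3 to compound 4 (0.58 log units; beyond the scatter) is the first measured change of ring size on this carbonyl carbon, and it shows that in this assay the position distinguishes a six-membered from a five-membered non-aromatic ring with one hetero atom, even though the counted hydrogen-bond donors, acceptors and net charge of the two groups are the same. The piperidin-1-yl group still reads better than methoxymethyl, a 3.8-fold lower number from compound 1 to compound 4 (0.58 log units; beyond the scatter), though that step is modest, whereas the pyrrolidin-1-yl group gave a 14-fold lower number from compound 1 to compound 3 (1.16 log units; beyond the scatter), so the large gain seen earlier does not belong to every saturated nitrogen ring on this carbonyl. The repeated entries available in this series span far less than the step from the five-membered to the six-membered ring: the several entries of compound 2 in this assay, 0.7 nM; 1 nM (2 entries)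

The compounds shown do not tell whether the trend continues in either direction, with azetidin-1-yl on the smaller side or azepan-1-yl on the larger. Nor do they tell how a second ring hetero atom would read, as in morpholin-4-yl or piperazin-1-yl on the same carbonyl carbon.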